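Amide chain branching in a kinase series: working notes

The source may hold more compounds than are shown below. What is called first, only, known or untested is meant among the compounds shown, and "the series" means these compounds.

Compound 2 `CCCCNC(=O)c1ccc2c(ccn2-c2ncc3c(n2)N(c2ccn(C)n2)C(CC)C(=O)N3C)c1` carries a butylcarbamoyl group; in an assay for inhibition of serine/threonine-protein kinase PLK3 (Homo sapiens), read by FRET and Z'-LYTE, with a stated time of 1 h (on this read-out higher numbers stand for weaker inhibition and lower numbers for stronger inhibition), compound 2 gives > 10000 nM, which is a limit of the assay and not a number. Among the measured compounds shown here, compound 1 `CCC1C(=O)N(C)c2cnc(-n3ccc4cc(C(=O)NC)ccc43)nc2N1c1ccn(C)n1`, the methylcarbamoyl counterpart, is the only other member measured so far. In this assay compound 1 gives > 10000 nM, again a limit rather than a number. The step from compound 1 to compound 2 is a step that the two limits leave unreadable from compound 1 to compound 2, and the limit of > 10000 nM in this assay, at which 2 of the 2 values shown sit, leaves no reading of how far apart the two actually sit. Compound 3 `CCC1C(=O)N(C)c2cnc(-n3ccc4cc(C(=O)NCC(C)C)ccc43)nc2N1c1ccn(C)n1` is the next member, formed by isopropyl in place of propyl on a saturated chain carbon bound to an amide-type nitrogen. For the measured compounds named here, only the step from compound 1 to compound 2 bears on this change, and its size cannot be read, so no direction can be drawn from it; with both measured values sitting at the limit, compound 3 is expected to stay there as well. The step this expectation implies in this assay is a step that the limit leaves unreadable from compound 2 to compound 3. Compound 3 is estimated at 15000 nM in this assay, within 5000 nM to 50000 nM.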

Compound 3, half-maximal inhibitory concentration: > 10000 nM
Compound 3: no number, only a limit; the forecaster's own chance of this, stated with the estimate: 85%; the middle value does not contradict the limit.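

In this assay compound 3 gives > 10000 nM, again a limit and not a number. No step among compound 1, compound 2 and compound 3 can therefore be read: the limit of > 10000 nM in this assay, at which 3 of the 3 values shown sit.

As far as these compounds go, whether the methylcarbamoyl, butylcarbamoyl and isobutylcarbamoyl compounds differ at all in inhibition remains open.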